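The source may hold more compounds than are shown below. What is called first, only, known or untested is meant among the compounds shown, and "the series" means these compounds.

The measured compounds:
compound 1 `Fc1cccc(F)c1NCn1nc(-c2ccc3c(c2)OCCO3)oc1=S` gives 3320 nM in a functional assay, with a stated time of 6 min; on this read-out lower numbers stand for stronger inhibition and higher numbers for weaker inhibition
compound 2 `S=c1oc(-c2ccc3c(c2)OCCO3)nn1CNc1ccccc1Cl` gives 7230 nM in this assay
compound 3 `S=c1oc(-c2ccc3c(c2)OCCO3)nn1CNc1cccc(Cl)c1` gives 6220 nM in this assay

Compound 1 stands at the lowest of the three numbers in this assay. Compound 3 lies within the scatter of it, as a 1.9-fold higher number from compound 1 to compound 3 (0.27 log units; within the scatter) shows, while compound 2 lies beyond it, as a 2.2-fold higher number from compound 1 to compound 2 (0.34 log units; beyond the scatter) shows; between the two chlorophenyl compounds the gap is a 1.2-fold lower number from compound 2 to compound 3 (0.07 log units; within the scatter).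

Compound 4 `COc1ccccc1NCn1nc(-c2ccc3c(c2)OCCO3)oc1=S` has not yet been measured. It differs from compound 1 in one place: 2-methoxyphenyl in place of 2,6-difluorophenyl on an amine nitrogen. Among the compounds with values here, no measured compound carries a 2-methoxyphenyl on the amine nitrogen, so no step bears directly on this change. The two steps that do replace the 2,6-difluorophenyl of compound 1, a 2.2-fold higher number from compound 1 to compound 2 (0.34 log units; beyond the scatter) and a 1.9-fold higher number from compound 1 to compound 3 (0.27 log units; within the scatter), both run to higher numbers, one beyond and one within the scatter. On that basis a modest rise is expected for compound 4 in this assay, amounting to a 1.7-fold higher number from compound 1 to compound 4 (0.22 log units; within the scatter). Compound 4 is therefore estimated at 5500 nM, with a range from 2500 nM to 12000 nM.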

Compound 4, half-maximal inhibitory concentration: 6300 nM
Beside the measured number, compound 4's estimate is 1.1-fold (0.06 log units) below it; measured number inside the range.
By their numbers in this assay, from the lowest: compounds 1, 3, 4 and 2 (each within the scatter of the next, the first and the last beyond it).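

In this assay the 2-methoxyphenyl group on the amine nitrogen cannot be told apart from either chlorophenyl group (a 1.0-fold higher number from compound 3 to compound 4 (0.01 log units; within the scatter)) and (methoxy in place of chloro on an aromatic carbon, a 1.1-fold lower number from compound 2 to compound 4 (0.06 log units; within the scatter)). The hydrogen-bond acceptor counted in the 2-methoxyphenyl therefore goes with no readable separation from the chlorophenyl compounds. Compound 4 also stays within the scatter of compound 1 (2-methoxyphenyl in place of 2,6-difluorophenyl, a 1.9-fold higher number from compound 1 to compound 4 (0.28 log units; within the scatter)), so among these four aromatic groups only the step to compound 2 (2-chlorophenyl, a 2.2-fold higher number from compound 1 to compound 2 (0.34 log units; beyond the scatter)) lies beyond the scatter.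

From the compounds shown here alone, it remains open whether a group of another kind on the amine nitrogen, such as a pyridine ring, a cyclohexyl ring or a carboxylic acid on the phenyl ring, would move the number further. No supporting evidence is available to account for how closely these groups agree.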